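Difluorophenyl Swap on a Triazole Amide Series

A few compounds are considered here, and "the series" means these few. Any claim that something is new, unique, unknown or untested is made for them only; others in the source may bear on it.

Measured in a functional assay on PC-3 cells (Homo sapiens) for cytotoxicity, read by MTT assay, with a stated time of 72 h (on this read-out lower numbers stand for stronger inhibition and higher numbers for weaker inhibition), so far:
compound 1 `Cc1c(C(=O)Nc2ccc(Oc3ccnc4[nH]ccc34)c(F)c2)nnn1-c1ccccc1` gives 2340 nM
compound 2 `Cc1c(C(=O)Nc2ccc(Oc3ccnc4[nH]ccc34)c(F)c2)nnn1-c1ccc(F)cc1` gives 4350 nM

Compound 3 `COc1ccc(-n2nnc(C(=O)Nc3ccc(Oc4ccnc5[nH]ccc45)c(F)c3)c2C)cc1` stands apart: in this assay compound 3 gives "not determined" (no result reported), so it gives no foothold of its own. Compound 4 `Cc1c(C(=O)Nc2ccc(Oc3ccnc4[nH]ccc34)c(F)c2)nnn1-c1ccc(F)c(F)c1` differs from it by 3,4-difluorophenyl in place of 4-methoxyphenyl on an aromatic nitrogen. Among the measured compounds shown here, only one measured step bears on this change, a 1.9-fold higher number from compound 1 to compound 2 (0.27 log units; within the scatter), a fluoro in place of hydrogen on an aromatic carbon of the same ring. That step stayed within the scatter. For the measured compounds named here, the second fluorine and the removal of the methoxy group have no counterpart among the measured compounds, so no step beyond the scatter is assumed either way. Compound 4 is therefore expected to give about 5000 nM in this assay, somewhere between 1800 nM and 14000 nM.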

Compound 4, half-maximal inhibitory concentration: 6540 nM
The estimate for compound 4 lay 1.3-fold (0.12 log units) below the measured number; low and high end bracket the measured number.
By their numbers in this assay, from the lowest: compounds 1, 2 and 4 (each within the scatter of the next, the first and the last beyond it).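

In this assay the second fluorine gives a 1.5-fold higher number from compound 2 to compound 4 (0.18 log units; within the scatter) and so, taken alone, cannot be told apart from repeat scatter. Across the whole change from phenyl to 3,4-difluorophenyl on the aromatic nitrogen, the two fluorines give a 2.8-fold higher number from compound 1 to compound 4 (0.45 log units; beyond the scatter) and so provide the first step at this position beyond the scatter, though a modest one, towards weaker inhibition. Nothing measured here offers a reason for this shift. Still open, on these data alone, is whether an amine or a carboxylic acid on this phenyl ring would move the number the other way.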